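A few compounds are considered here, and "the series" means these few. Any claim that something is new, unique, unknown or untested is made for them only; others in the source may bear on it.

Compound 1 `COC(=O)N[C@H](C(=O)NN(CCC[C@@](O)(Cc1ccccc1)C(=O)N[C@H]1c2ccccc2C[C@H]1O)Cc1ccccc1)C(C)(C)C` is the reference point of this set. In an ADME assay on MT4 cells (Homo sapiens) for cytotoxicity (a lower number here means that less compound is tolerated, a higher number that more compound is tolerated), compound 1 gives > 10000 nM, which is a limit of the assay rather than a number. Compound 2 `COC(=O)N[C@H](C(=O)NN(CCC[C@@](O)(Cc1ccccc1)C(=O)N[C@H]1c2ccccc2C[C@H]1O)Cc1ccc(C#N)cc1)C(C)(C)C` carries cyano in place of hydrogen on an aromatic carbon. In this assay compound 2 gives > 10000 nM, again a limit. The step that the two limits leave unreadable from compound 1 to compound 2 cannot be read because the limit of > 10000 nM in this assay, at which 2 of the 2 values shown sit, leaves both values at the same limit. Compound 3 `COC(=O)N[C@H](C(=O)NN(CCC[C@@](O)(Cc1ccccc1)C(=O)N[C@H]1c2ccccc2C[C@H]1O)Cc1ccc(-c2ccccn2)cc1)C(C)(C)C` is reached from compound 1 by the change (pyridin-2-yl in place of hydrogen on an aromatic carbon). Among the compounds with values here, the only measured step at the same aromatic carbon is the one from compound 1 to compound 2, and its size is unreadable, so no measured step tells how a pyridin-2-yl group at this place moves the read-out in this assay. Since compound 1 shows only a limit, compound 3 is expected to be tolerated to the limit of this assay as well. The estimated step that the limit leaves unreadable from compound 1 to compound 3 is therefore expected to be small. Compound 3 is estimated at 15000 nM, in the range 5000 nM to 50000 nM, with a fair chance that only a limit is reported again.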

Compound 3, half-maximal cytotoxic concentration: > 10000 nM
Compound 3 ended at the assay's limit (the forecaster's own chance of this, stated with the estimate: 75%); the middle value lies beyond the limit too.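

Within the data shown here, no step among compound 1, compound 2 and compound 3 can be read in this assay, because all three values are limits and none is a number: the limit of > 10000 nM in this assay, at which 3 of the 3 values shown sit.

The compounds shown leave open how much of each compound is tolerated beyond that limit, and whether cyano or pyridin-2-yl in place of hydrogen on the aromatic carbon shifts the read-out at all.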